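Ethyl to sec-butyl in a series at its limit

This account rests on a few compounds, and the source may have more. Where it says the series, first, only, none or still open, it means among the compounds named here.

Of the compounds shown here, two have been read so far in an ADME assay on Vero cells (Chlorocebus sabaeus) for cytotoxicity, read by neutral red uptake, with a stated time of 3 days; on this read-out higher numbers stand for lower toxicity in this test and lower numbers for higher toxicity in this test: compound 1 `CC(CN(C)C)NC(=O)c1cc(C2CC2)nc2c1cnn2C(C)C` and compound 2 `CCn1ncc2c(C(=O)NCCN(C)C)cc(C3CC3)nc21`. Compound 1 gives > 300000 nM, which is a limit of the assay and not a number. Compound 2 gives > 300000 nM, which is likewise a limit and not a number. Compound 2 thus stands at the limit of > 300000 nM in this assay, at which 2 of the 2 values shown sit, and the two compounds cannot be ordered in this assay.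

Compound 3 `CCC(C)n1ncc2c(C(=O)NCCN(C)C)cc(C3CC3)nc21` carries ethyl in place of hydrogen on a saturated chain carbon bound to an aromatic nitrogen and a saturated chain carbon. The same difference reads ethyl to sec-butyl, and it counts as ethyl in place of hydrogen on a saturated chain carbon bound to an aromatic nitrogen and a saturated chain carbon.

Within the data shown here, no step between measured compounds is available to size this change. No step beyond the scatter is expected in this assay, and another report as a limit is the likeliest outcome. That expectation rests only on compound 2 and its limit of > 300000 nM. The estimated step is a number no higher from compound 2 to compound 3 (the limit leaves the size open). For compound 3 the estimate is 300000 nM, with an expected range of 130000 nM to 500000 nM.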

Compound 3, half-maximal cytotoxic concentration: 101000 nM
For compound 3 the middle estimate is 3.0-fold (0.47 log units) above the measured one, outside the stated range (below it).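

In this assay, among these compounds, ethyl in place of hydrogen on a saturated chain carbon bound to an aromatic nitrogen and a saturated chain carbon gives an at least 2.9-fold lower number from compound 2 to compound 3 (0.47 log units; beyond the scatter), so this place can move the read-out towards higher toxicity in this test, which the earlier compounds could not show. Compound 3 is the only compound shown that reads as a number and not as a limit of the assay: the limit of > 300000 nM in this assay, at which 2 of the 3 values shown sit. Going by these compounds, compound 2 gives > 300000 nM, which is a limit and not a number, so the step fixes only a smallest size and its full size remains unknown.

With ethyl and sec-butyl alone, the effects of chain length and branching cannot be told apart, and a straight butyl chain or a cyclopentyl group at this place would be needed to separate them. On these data alone, whether a hydroxyl group or an amine on the sec-butyl chain would bring the read-out back to the limit also remains open.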